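The compounds below may be only part of what the source reports. "The series", "measured", "known", "first", "only" and "open" are said of these compounds alone.

Measured so far in an assay (brain) for inhibition of Fatty-acid amide hydrolase 1 (Mus musculus), with stated times of 20 min and 15 min; on this read-out higher numbers stand for weaker inhibition and lower numbers for stronger inhibition:

- compound 1 `NC(=O)c1ccn(-c2cccc(OC(=O)NCCCCCCc3ccccc3)c2)c1` gives 0.16 nM
- compound 2 `Cc1cc(C(N)=O)c(-c2cccc(OC(=O)NCCCCCCc3ccccc3)c2)o1` gives 0.49 nM
- compound 3 `NC(=O)c1ccn(-c2cccc(OC(=O)NCCOCCOc3ccccc3)c2)c1` gives 23 nM

Compound 3 gives the highest number of the three in this assay, its nearest neighbour being compound 2 and the furthest compound 1. The two measured steps are a 3.1-fold higher number from compound 1 to compound 2 (0.49 log units; beyond the scatter), a change of the heteroaryl carboxamide, and a 140-fold higher number from compound 1 to compound 3 (2.16 log units; beyond the scatter), a change of the chain that carries the terminal phenyl. Neither touches the terminal phenyl itself.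

Compound 4 `NC(=O)c1ccn(-c2cccc(OC(=O)NCCOCCOc3c(F)cc(F)cc3F)c2)c1` differs from compound 3 by 2,4,6-trifluorophenyl in place of phenyl on an oxygen on a saturated carbon. Among the measured compounds shown here, no measured step bears on this change, so the expectation rests only on compound 3 and its value 23 nM, and on the absence of any precedent for a substituent on the terminal ring altering the number in this assay. The step of a 1.2-fold lower number from compound 3 to compound 4 (0.06 log units; within the scatter) is therefore expected to be small, likely within the scatter, with no direction preferred. For compound 4 the number in this assay is estimated at 20 nM, within 6 nM to 65 nM.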

Compound 4, inhibition constant: 11 nM
Beside the measured number, compound 4's estimate is 1.8-fold (0.26 log units) above it; the range from low to high includes it.
By their numbers in this assay, from the lowest: compound 1; then compound 2; then compound 4; then compound 3.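

In this assay, among the compounds shown here, the terminal ring is changed for the first time: 2,4,6-trifluorophenyl in place of phenyl, on an oxygen on a saturated carbon, gives a 2.1-fold lower number from compound 3 to compound 4 (0.32 log units; beyond the scatter). This position therefore accepts the added fluorine atoms with no loss of inhibition, and the number moves modestly towards stronger inhibition. The step is much smaller than the chain change, a 140-fold higher number from compound 1 to compound 3 (2.16 log units; beyond the scatter), and nothing at hand gives a reason for the shift.

The compounds shown do not separate the contributions of the three fluorine atoms, so the outcome with 4-fluorophenyl, 4-methoxyphenyl or pyridyl in place of phenyl remains open. Also open, on these data alone, is whether 2,4,6-trifluorophenyl at the end of the all-carbon chain of compound 1 would move the number in the same direction.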